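This account rests on a few compounds, and the source may have more. Where it says the series, first, only, none or still open, it means among the compounds named here.

Compound 1, with structure `Cn1ncc(Cl)c1-c1cc(C(=O)N[C@@H]2CN[C@H](CCn3cncn3)C[C@H]2c2ccc(Cl)c(Cl)c2)oc1Cl`, is tested in a functional assay on HCT-116 cells (Homo sapiens) for antiproliferative activity, read by sulforhodamine B assay, with a stated time of 72 h (on this read-out lower numbers stand for stronger inhibition and higher numbers for weaker inhibition), where compound 1 gives 560 nM. Among the three measured compounds, compound 1 holds the second highest number. Its nearest neighbour is compound 3, with structure `Cn1ncc(Cl)c1-c1cc(C(=O)N[C@@H]2CN[C@H](CC(=O)NC3CCC3)C[C@H]2c2ccc(Cl)c(Cl)c2)oc1Cl`, where compound 3 gives 430 nM; the furthest is compound 2, with structure `O=C(N[C@@H]1CNCC[C@H]1c1ccc(Cl)cc1)c1ccc(-c2ncnc3c2CCC3O)s1`, where compound 2 gives 23000 nM, a number far higher than that of compound 1. Going by the values given here, no single-point step links compound 2 to compound 1, so only the two values themselves can be set side by side.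

The unmeasured compound 4, with structure `CNC(=O)C[C@@H]1C[C@@H](c2ccc(Cl)c(Cl)c2)[C@H](NC(=O)c2cc(-c3c(Cl)cnn3C)c(Cl)o2)CN1`, differs from compound 1 in one place: methylcarbamoyl in place of (1H-1,2,4-triazol-1-yl)methyl on a saturated chain carbon bound to a saturated ring carbon. Among the compounds with values here, the one measured step that bears on this change is a 1.3-fold lower number from compound 1 to compound 3 (0.11 log units; within the scatter), in which a carbamoyl group also replaced the same heterocyclic group at the same place. That step stayed within the scatter, so a step of similar size is expected here, with no direction beyond the scatter. Compound 4 is therefore estimated at 500 nM, in a range from 200 nM to 1300 nM, which means an expected step of a 1.1-fold lower number from compound 1 to compound 4 (0.05 log units; within the scatter).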

Compound 4, half-maximal inhibitory concentration: 450 nM
Compound 4: middle estimate off by 1.1-fold (0.05 log units), on the high side; the range from low to high includes it.
By their numbers in this assay, from the lowest: compounds 3, 4 and 1 (each within the scatter of the next); then compound 2.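

In this assay, a second carbamoyl group now stands in for (1H-1,2,4-triazol-1-yl)methyl on a saturated chain carbon bound to a saturated ring carbon, and it gives a 1.2-fold lower number from compound 1 to compound 4 (0.09 log units; within the scatter). Two different carbamoyl groups have therefore replaced the heterocyclic group at this place, each with a step inside the scatter. The result also adds a change on the amide-type nitrogen itself, where methyl and cyclobutyl read alike, with a 1.0-fold higher number from compound 3 to compound 4 (0.02 log units; within the scatter).

As far as these compounds go, whether a carboxylic acid, an amine or a longer chain at this place would keep the number in the same range stays open. Nothing in the data shown offers an explanation for why these three groups read alike.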